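This account rests on a few compounds, and the source may have more. Where it says the series, first, only, none or still open, it means among the compounds named here.

Compound 1, `Cc1nn(C)c2c1C(c1cccc(Cl)c1)=NCCN2C`: in a functional assay on the whole organism for positive allosteric modulation, with Rattus norvegicus as the target (on this read-out lower numbers stand for an effect already at smaller amounts and higher numbers for an effect only at larger amounts of compound), compound 1 gives 0.63 mg/kg.
Compound 2, `Cc1nn(C)c2c1C(c1cccc(Cl)c1)=NCCN2N=O`: in this assay compound 2 gives 1.25 mg/kg.

Among the measured compounds shown here, compound 2 stands at the higher of the two numbers so far, yet the gap between them is only a 2.0-fold higher number from compound 1 to compound 2 (0.30 log units; within the scatter), a step within the scatter, so the two compounds cannot be told apart on this read-out.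

Compound 3, `Cc1nn(C)c2c1C(c1cccc(Cl)c1)=NCCN2CCN1CCCC1`, has not yet been measured. It differs from compound 2 in one place: a group of 7 heavy atoms (6 carbon, 1 nitrogen; one five-membered non-aromatic ring with 1 hetero atom) in place of a group of 2 heavy atoms (1 nitrogen, 1 oxygen; no ring), on a nitrogen on an aromatic ring in a ring. For the measured compounds named here, the only measured step at this position is a 2.0-fold higher number from compound 1 to compound 2 (0.30 log units; within the scatter), which concerned a much smaller change and stayed within the scatter. Nothing measured speaks to a 2-(pyrrolidin-1-yl)ethyl group at this nitrogen, so no direction can be read from the data, and the account expects no step beyond the scatter in this assay; the expected step is no change at the digits printed from compound 2 to compound 3 (within the scatter). Going by the values given here, compound 3 is therefore estimated at 1.25 mg/kg, with a range from 0.3 mg/kg to 5 mg/kg, a range kept wide since the only guide is a 2.0-fold higher number from compound 1 to compound 2 (0.30 log units; within the scatter).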

Compound 3, minimum effective dose: > 10 mg/kg
Compound 3 was reported as a limit; the forecaster's own chance of this, stated with the estimate: 10%; middle value at least 8.0-fold (0.90 log units) from the limit.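

In this assay, among the compounds shown here, the nitrogen on an aromatic ring in the seven-membered ring now proves sensitive to the group it carries, which the first two compounds could not show, as their single step stayed within the scatter. Putting 2-(pyrrolidin-1-yl)ethyl on this nitrogen gives an at least 8.0-fold higher number from compound 2 to compound 3 (0.90 log units; beyond the scatter), and set against the methyl-bearing compound the same group gives an at least 15-fold higher number from compound 1 to compound 3 (1.20 log units; beyond the scatter), so the position does not accept every substituent without consequence in the whole animal. The reading for compound 3 is a limit of the assay and not a number: the limit of > 10 mg/kg in this assay, at which 1 of the 3 values shown sits.

The compounds shown cannot separate the parts of the new group, so it remains open whether a plain carbon chain such as n-butyl, a shorter or longer chain ending in the same pyrrolidine, or an open-chain amine such as 2-(diethylamino)ethyl would behave like compound 3 or like compound 1. From the compounds shown here alone, it also remains open whether a neutral ring such as 2-(morpholin-4-yl)ethyl or a simple ethyl group would keep the effect at the smaller doses seen for the first two compounds.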